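Bromo for Chloro Carried onto a Second Core

A few compounds are considered here, and "the series" means these few. Any claim that something is new, unique, unknown or untested is made for them only; others in the source may bear on it.

Measured in a functional assay (Cavia porcellus) with Rattus norvegicus as the target; a lower number here means that less compound is needed, a higher number that more compound is needed for the effect:
Compound 1 `CC1=CS[C@@](O)(c2ccc(Cl)cc2)c2noc(=O)n21` gives 800 nM.
Compound 2 `CC1=CS[C@@](O)(c2ccc(Br)cc2)c2noc(=O)n21` gives 320 nM.
Compound 3 `CC/C=C\COC1(c2ccc(Cl)cc2)SC=C(C)n2c1noc2=O` gives 1310 nM.

Compound 2 differs from compound 1 by bromo in place of chloro on an aromatic carbon; this gave a 2.5-fold lower number from compound 1 to compound 2 (0.40 log units; beyond the scatter). Compound 3 rests on another core, and the difference between the two cores is not broken down here; its number is the highest of the three, close to that of compound 1 and beyond the scatter from that of compound 2. Compound 4 `CC/C=C\COC1(c2ccc(Br)cc2)SC=C(C)n2c1noc2=O` differs from compound 3 by bromo in place of chloro on an aromatic carbon, the same change at the same place. In this assay a step of a 2.4-fold lower number from compound 3 to compound 4 (0.38 log units; beyond the scatter) is expected, because the same change gave a 2.5-fold lower number from compound 1 to compound 2 (0.40 log units; beyond the scatter). Compound 4 is therefore estimated at 550 nM, expected between 280 nM and 1200 nM.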

Compound 4, half-maximal effective concentration: 630 nM
Compound 4: middle estimate off by 1.1-fold (0.06 log units), on the low side; the measured number falls inside the stated range.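

In this assay, bromo in place of chloro on the core of compound 3 gave a 2.1-fold lower number from compound 3 to compound 4 (0.32 log units; beyond the scatter), so the change carried over to the second core with a step that matches the first: the same change on two cores in this assay, a 2.5-fold lower number (0.40 log units; beyond the scatter) from compound 1 to compound 2 and a 2.1-fold lower number (0.32 log units; beyond the scatter) from compound 3 to compound 4, 1.2-fold (0.08 log units) apart, within the scatter of two such steps. Within the data shown here, this agreement rests on one change, 4-chlorophenyl to 4-bromophenyl, on only two cores. It does not show that the step would hold on any further core, that other changes would carry over in the same way, or why bromo gives the lower number on both. The compounds shown leave open what fluoro, iodo or methoxy in the same place would give on either core.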